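The source may report more compounds than this note shows. Statements on the series, on what has been measured and on what is new or still open speak of the compounds shown alone.

Measured so far in a functional assay on PC-12 cells (Rattus norvegicus) for cytotoxicity, read by MTT assay, with stated times of 2 h and 24 h, tested at 1 uM; on this read-out lower numbers stand for a weaker effect and higher numbers for a stronger effect at the one concentration tested:

- compound 1 `Oc1cc(C(F)(F)F)ccc1-c1nc(-c2ccccc2O)n(-c2ccc(F)cc2)n1`: 67.2%
- compound 2 `Oc1cc(C(F)(F)F)ccc1-c1nc(-c2ccccc2O)n(-c2ccccc2C(F)(F)F)n1`: 71%
- compound 3 `Oc1cc(C(F)(F)F)ccc1-c1nc(-c2ccccc2O)n(-c2cccc(F)c2)n1`: 67.2%

Compound 3 sits level with compound 1, the two of them giving the smaller of the three figures, while compound 2 is the furthest away; every gap among the three is within the scatter. The move from compound 1 to compound 3 is no change at the digits printed from compound 1 to compound 3 (within the scatter), that from compound 2 to compound 3 is a number 3.8 percentage points lower from compound 2 to compound 3 (within the scatter), and the remaining pair shows a number 3.8 percentage points higher from compound 1 to compound 2 (within the scatter).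

The next compound is compound 4 `Cc1ccc(-n2nc(-c3ccc(C(F)(F)F)cc3O)nc2-c2ccccc2O)c(C)c1`. Its difference from compound 3 is 2,4-dimethylphenyl in place of 3-fluorophenyl on an aromatic nitrogen.

All three measured steps bear on this change, since each of them also exchanges the aryl group on the same aromatic nitrogen of the shared core, and none of them moved this assay beyond the scatter. On that basis no step beyond the scatter is expected in this assay from compound 3 to compound 4, and the estimated step is a number 0.8 percentage points higher from compound 3 to compound 4 (within the scatter).

Compound 4 is therefore estimated at 68% in this assay, with a range of 58% to 78%.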

Compound 4, a percentage reported as activity, at one concentration (the size of the read-out at that concentration, not a potency): 73.7%
The estimate for compound 4 lay 5.7 percentage points below the measured number, and the stated range covers the measured number.
By their numbers in this assay, from the lowest: compounds 1, 3, 2 and 4 (each within the scatter of the next).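

In this assay, 2,4-dimethylphenyl is the only one of the four aryl groups on this aromatic nitrogen that carries no fluorine, yet exchanging each fluorine-bearing group for it stays within the scatter (a number 6.5 percentage points higher from compound 3 to compound 4 (within the scatter); a number 6.5 percentage points higher from compound 1 to compound 4 (within the scatter); a number 2.7 percentage points higher from compound 2 to compound 4 (within the scatter)). The position therefore also accepts a phenyl ring with two methyl groups, including one placed so that the group is substituted as in 2-(trifluoromethyl)phenyl, and no preference among these four aryl groups can be read from this assay. No measurement given here accounts for the size of these steps.

The compounds shown leave open whether a phenyl ring bearing a carboxylic acid or an amine, or a longer alkyl chain in place of the aryl ring, would move this read-out beyond the scatter at this nitrogen. Going by these compounds, all four compounds also share the same core with its 2-hydroxyphenyl group, so the contribution of those parts remains open, and a result at one concentration gives the size of the effect rather than a potency.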